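From compound 2 to compound 3: one group exchanged

The source may report more compounds than this note shows. Statements on the series, on what has been measured and on what is new or still open speak of the compounds shown alone.

Compound 1 `O=C1C(=Cc2ccc(F)cc2)C(=O)N(c2ccc(Cl)cc2)N1c1ccc(Cl)cc1`: 31400 nM
Compound 2 `COc1cccc(C=C2C(=O)N(c3ccc(Cl)cc3)N(c3ccc(Cl)cc3)C2=O)c1O`: 26700 nM

Both values come from a functional assay on MCF7 cells (Homo sapiens) for cytotoxicity, read by MTT assay, with a stated time of 72 h; a higher number here means a weaker inhibitor, a lower number a stronger inhibitor. For the measured compounds named here, only one step between measured compounds is known so far: a 1.2-fold lower number from compound 1 to compound 2 (0.07 log units; within the scatter). Compound 2 therefore stands level with compound 1, and neither can be called the stronger. The next compound, compound 3 `COc1ccc(C=C2C(=O)N(c3ccc(Cl)cc3)N(c3ccc(Cl)cc3)C2=O)cc1OC`, keeps the core of compound 2 and changes one group: 3,4-dimethoxyphenyl in place of 2-hydroxy-3-methoxyphenyl on a double-bonded chain carbon bound to a double-bonded ring carbon. This change falls at the same place as the measured step, where one group exchanged for another left the number within the scatter. Going by the values given here, that single step is the only guide, and no measured step shows what the new group does on its own. The expected step is therefore none beyond the scatter in this assay: a 1.0-fold higher number from compound 2 to compound 3 (0.02 log units; within the scatter). The estimate for compound 3 is 28000 nM, with an expected range from 13000 nM to 60000 nM.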

Compound 3, half-maximal inhibitory concentration: > 128000 nM
Compound 3 ended at the assay's limit; the forecaster's own chance of this, stated with the estimate: 10%; middle value at least 4.5-fold (0.66 log units) from the limit.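

In this assay, the group on the double-bonded chain carbon bound to a double-bonded ring carbon can clearly move the number: 3,4-dimethoxyphenyl brings an at least 4.7-fold higher number from compound 2 to compound 3 (0.68 log units; beyond the scatter), and also an at least 4.0-fold higher number from compound 1 to compound 3 (0.61 log units; beyond the scatter). The earlier exchange at this place stayed within the scatter, so it gave no sign that a change here could reach beyond it. Compound 3 stands at a limit of the assay, not at a true number, so both steps give only the smallest possible size: the limit of > 128000 nM in this assay, at which 1 of the 3 values shown sits.

Still open, as far as these compounds go, is whether the hydrogen-bond donor of 2-hydroxy-3-methoxyphenyl matters on its own, as the entering group differs in more than that one feature. Also open, from the compounds shown here alone, is what a phenyl ring carrying an amine or a carboxylic acid would do at this place.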